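Halogenated Benzyl Replaces Methoxybenzyl on the Nucleoside Core

The compounds below may be only part of what the source reports. "The series", "measured", "known", "first", "only" and "open" are said of these compounds alone.

Compound 2 `COc1ccccc1CNc1ncnc2c1ncn2[C@@H]1O[C@H](CO)[C@@H](O)[C@H]1O` has been tested in a functional assay on K562 cells (Homo sapiens) for antiproliferative activity, with a stated time of 72 h (on this read-out higher numbers stand for weaker inhibition and lower numbers for stronger inhibition), where compound 2 gives 89000 nM. Among the numbers recorded so far, compound 2 stands lowest; its nearest neighbour is compound 1 `OC[C@H]1O[C@@H](n2cnc3c(NCc4ccc(Cl)cc4)ncnc32)[C@H](O)[C@@H]1O`, which in this assay gives 218000 nM. Compound 3 `OC[C@H]1O[C@@H](n2cnc3c(NCc4cc(F)cc(F)c4)ncnc32)C(O)C1O` in this assay gives only a limit of the assay, > 166000 nM. Going by the values given here, the single measured step, a 2.4-fold lower number from compound 1 to compound 2 (0.39 log units; beyond the scatter), shows that 2-methoxyphenyl in place of 4-chlorophenyl lowers the number by a modest amount. Compound 4 `OC[C@H]1O[C@@H](n2cnc3c(NCc4ccc(F)c(Cl)c4)ncnc32)[C@H](O)[C@@H]1O` has not yet been measured. It differs from compound 2 in one place: 3-chloro-4-fluorophenyl in place of 2-methoxyphenyl on a saturated chain carbon bound to a nitrogen on an aromatic ring. This change returns to a halogen-bearing phenyl, so the step from compound 1 to compound 2 bears on it in reverse, and the limit for compound 3 the limit of > 166000 nM in this assay, at which 1 of the 3 values shown sits, points the same way, though the whole picture rests on two numbers and one limit. A rise in the number is therefore expected, of roughly the size seen before, a 2.2-fold higher number from compound 2 to compound 4 (0.35 log units; beyond the scatter). The value for compound 4 is estimated at 200000 nM, with a range from 80000 nM to 500000 nM, and a real chance that the assay reports only a limit.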

Compound 4, half-maximal inhibitory concentration: 5500 nM
Compound 4: the middle estimate sits 36-fold (1.56 log units) above what was measured, outside the stated range (below it).
By their numbers in this assay, from the lowest: compound 4; then compound 2; then compound 1.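

In this assay, the step to the 3-chloro-4-fluorophenyl group is far larger than the earlier change at this position suggested: a 16-fold lower number from compound 2 to compound 4 (1.21 log units; beyond the scatter), and a 40-fold lower number from compound 1 to compound 4 (1.60 log units; beyond the scatter). Carrying a halogen therefore does not by itself set the number here, as compound 1 and compound 4 both bear halogen on the phenyl yet sit far apart, so what counts among these compounds is which phenyl group is attached, and compound 1 goes against any simple rule that halogen lowers the number. Compound 3, also halogen-bearing, gives only a limit of the assay: the limit of > 166000 nM in this assay, at which 1 of the 4 values shown sits.

The compounds shown leave open whether the chlorine or the fluorine of the 3-chloro-4-fluorophenyl group accounts for the drop, or whether the two are needed together. Also open, on these data alone, is whether the low number would survive a longer chain in place of the saturated chain carbon bound to the nitrogen, or an amine or a carboxylic acid on the phenyl ring.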